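The source may hold more compounds than are shown below. What is called first, only, known or untested is meant among the compounds shown, and "the series" means these compounds.

Measured so far in a functional assay on A-375 cells (Homo sapiens) for inhibition, read by MTT assay, with a stated time of 72 h; on this read-out higher numbers stand for weaker inhibition and lower numbers for stronger inhibition:
- compound 1 `CC(C)c1ccc(Nc2ccc(C(=O)C(Cl)Cl)cc2[N+](=O)[O-])cc1` at 900 nM
- compound 2 `CC(C)(C)c1ccc(Nc2ccc(C(=O)C(Cl)Cl)cc2[N+](=O)[O-])cc1` at 900 nM

Among the compounds with values here, compound 2 stands level with compound 1, the only other compound measured, and it carries a tert-butyl group on the shared core. The next compound is compound 3 `CC(C)(O)c1ccc(Nc2ccc(C(=O)C(Cl)Cl)cc2[N+](=O)[O-])cc1`, where tert-butyl becomes 1-hydroxy-1-methylethyl. The change is counted in hydroxy in place of methyl on a saturated chain carbon bound to an aromatic carbon and two saturated chain carbons and it puts hydroxy in place of methyl on a saturated chain carbon bound to an aromatic carbon and two saturated chain carbons.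

Within the data shown here, only one measured step bears on this carbon. That step is no change at the digits printed from compound 1 to compound 2 (within the scatter) for methyl in place of hydrogen. Among the measured compounds shown here, it shows that an added methyl left the value where it was, but it tests no hydroxy, and no measured compound carries one. The direction is therefore a judgement, and a modest rise in the number, meaning weaker inhibition, is expected, with no change still quite possible. The expected step is a 2.2-fold higher number from compound 2 to compound 3 (0.35 log units; beyond the scatter) as an estimate only. Compound 3 is estimated at 2000 nM with an expected range from 800 nM to 6000 nM as a working figure.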

Compound 3, half-maximal inhibitory concentration: 1800 nM
Beside the measured number, compound 3's estimate is 1.1-fold (0.05 log units) above it; the range from low to high includes it.
By their numbers in this assay, from the lowest: compounds 1, 2 and 3 (each within the scatter of the next).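

Within the data shown here, on this saturated chain carbon, a hydroxy group can now be read for the first time: in this assay, hydroxy in place of methyl gives a 2.0-fold higher number from compound 2 to compound 3 (0.30 log units; within the scatter) and hydroxy in place of hydrogen gives a 2.0-fold higher number from compound 1 to compound 3 (0.30 log units; within the scatter) on the same shared core. Where the added methyl of compound 2 brought no hydrogen-bond donor or acceptor, the hydroxy of compound 3 brings one of each, and neither step can be told apart from the ordinary spread of repeated measurements, so these three compounds show no real difference at this position. Nothing measured here speaks to why the numbers fall as they do.

Going by these compounds, it remains open how this carbon would read with an amine, a methoxy group, a carboxylic acid or a longer chain in place of the hydroxy, since all three groups seen so far give numbers within the scatter of one another. On these data alone, it is also open whether the same hydroxy swap would read alike on a core carrying something other than the dichloroacetyl and nitro groups shared here.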